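This account rests on a few compounds, and the source may have more. Where it says the series, first, only, none or still open, it means among the compounds named here.

Series measured in an in vivo ADME assay on the whole organism (Cavia porcellus); a lower number here means that the compound disappears faster, a higher number that the compound lasts longer:

- compound 1 `CC(C)C(NC(=O)c1ccc(C(=N)N)cc1)C(C)(C)C(=O)N1CCC(CC(=O)O)CC1`: 0.8 h
- compound 2 `CC(C)CC(NC(=O)c1ccc(C(=N)N)cc1)C(C)(C)C(=O)N1CCC(CC(=O)O)CC1`: 0.917 h
- compound 3 `CC(C)(C(=O)N1CCC(CC(=O)O)CC1)C(CCc1ccccc1)NC(=O)c1ccc(C(=N)N)cc1`: 0.767 h

Compound 3, at 0.767 h, stands within the scatter of both other compounds, so the three values show no order. The next compound is compound 4 `CC(C)(C(=O)N1CCC(CC(=O)O)CC1)C(NC(=O)c1ccc(C(=N)N)cc1)c1ccc(Cl)cc1`, with the change 4-chlorophenyl in place of phenethyl on a saturated chain carbon bound to an amide-type nitrogen and a saturated chain carbon.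

The measured steps that bear on this all concern the group on that same carbon. They are a 1.1-fold higher number from compound 1 to compound 2 (0.06 log units; within the scatter), a 1.0-fold lower number from compound 1 to compound 3 (0.02 log units; within the scatter) and a 1.2-fold lower number from compound 2 to compound 3 (0.08 log units; within the scatter). Isopropyl, isobutyl and phenethyl therefore give values that cannot be told apart in this assay. None of the three measured compounds carries 4-chlorophenyl on this carbon, and this leaves the new group untested, so the range is set wider than the spread of the three values.

No shift beyond the scatter is expected in this assay, in either direction. The expected step is a 1.0-fold higher number from compound 3 to compound 4 (0.02 log units; within the scatter). For compound 4 the estimated half-life is 0.8 h, with an expected range of 0.5 h to 1.3 h.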

Compound 4, half-life: 1.2 h
Compound 4: middle estimate off by 1.5-fold (0.18 log units), on the low side; low and high end bracket the measured number.
By their numbers in this assay, from the lowest: compounds 3, 1, 2 and 4 (each within the scatter of the next).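

In this assay, among these compounds, 4-chlorophenyl is the only group on this saturated chain carbon that carries chlorine, and its steps from the other three groups all stay within the scatter: a 1.6-fold higher number from compound 3 to compound 4 (0.19 log units; within the scatter), a 1.3-fold higher number from compound 2 to compound 4 (0.12 log units; within the scatter) and a 1.5-fold higher number from compound 1 to compound 4 (0.18 log units; within the scatter). The set of groups at this place that cannot be told apart in this assay therefore now extends to a chlorine-bearing aromatic ring, alongside isopropyl, isobutyl and phenethyl, and no step among these four compounds lies beyond the scatter. No supporting measurement is available that would explain these half-lives or tie them to any feature of the groups.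

Plain phenyl on this carbon would show whether the chlorine has any bearing on the half-life, although a step from compound 4 would have to exceed the scatter to be read. As far as these compounds go, it also remains open whether a group of another kind at this place, such as an amine, a carboxylic acid or a longer chain carrying a hydroxyl group, would move the half-life beyond the scatter of the values seen so far.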